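This account rests on a few compounds, and the source may have more. Where it says the series, first, only, none or still open, it means among the compounds named here.

Compound 1 `O=C1CCC2(c3ccc(F)cc3)OCCCN12` was examined in a functional assay on the whole organism (Central nervous system) for activation, with Mus musculus as the target (on this read-out lower numbers stand for an effect already at smaller amounts and higher numbers for an effect only at larger amounts of compound), where compound 1 gives 75 mg/kg. Of the two numbers in hand, that of compound 1 is the lowest; the nearest is compound 2 `O=C(CCC(=O)c1ccc(F)cc1)NCCCO`, which in this assay gives 300 mg/kg, a gap beyond the usual scatter. Compound 3 `O=C1CCC2(c3ccc(Cl)cc3)OCCCN12` differs from compound 1 by chloro in place of fluoro on an aromatic carbon, para to a large group. Among the compounds with values here, no measured pair shows this exchange. The step from compound 1 to compound 3 is expected to stay within the scatter, if anything slightly downward. Compound 3 is therefore estimated at 60 mg/kg, in the range 30 mg/kg to 150 mg/kg. The expected step is a 1.3-fold lower number from compound 1 to compound 3 (0.10 log units; within the scatter).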

Compound 3, dose for half-maximal effect: 75 mg/kg
For compound 3 the middle estimate is 1.3-fold (0.10 log units) below the measured one; measured number inside the range.
By their numbers in this assay, from the lowest: compounds 1 and 3 (each within the scatter of the next); then compound 2.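

Within the data shown here, the exchange of fluoro for chloro on an aromatic carbon, para to a large group, gives no change at the digits printed from compound 1 to compound 3 (within the scatter) in this assay and is the first reading at this position. Within the scatter, this position accepts either halogen on the core of compound 1. Nothing on hand bears on the reason for this outcome.

As far as these compounds go, it remains open whether methoxy, an amine or a carboxylic acid at this place would shift the number beyond the scatter. Also open, from the compounds shown here alone, is whether chloro would behave in the same way on the open-chain compound 2.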